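Swapping one small ring for another: metabolic stability expected

The compounds below may be only part of what the source reports. "The series", "measured", "known", "first", "only" and "open" are said of these compounds alone.

Of the compounds shown here, two have so far been measured in an ADME assay on microsomes from liver (Homo sapiens) for metabolic stability, read by LC-MS, using NADPH, with stated times of 5 min and 30 min, tested at 1 uM; on this read-out lower numbers stand for slow clearance and higher numbers for fast clearance. Compound 1 `Cc1nccn1-c1cnc(NCc2c(F)ccc3c2CCO3)c2cn[nH]c(=O)c12` gives 8 mL.min-1.g-1. Compound 2 `O=C(Nc1cnc(NCc2c(F)ccc3c2CCO3)n2cnnc12)c1ccccc1`, which has a different core, gives 10 mL.min-1.g-1. These two numbers sit within the usual scatter of one another, so compound 1 cannot be set apart from compound 2 on this read-out; both stand at the slow-clearance end of what has been seen.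

Compound 3 `Cn1nccc1-c1cnc(NCc2c(F)ccc3c2CCO3)c2cn[nH]c(=O)c12` keeps the core of compound 1 and differs from it in one place: 1-methyl-1H-pyrazol-5-yl in place of 2-methyl-1H-imidazol-1-yl on an aromatic carbon. Both groups have the same count of atoms, the same kind of five-membered aromatic ring with two hetero atoms, and the same count of hydrogen-bond donors and acceptors. Among the measured compounds shown here, there is no measured pair in this set that isolates such a swap, so no measured step can guide the expectation.

Given that, the step of a 1.1-fold higher number from compound 1 to compound 3 (0.05 log units; within the scatter) is expected to stay within the scatter, in no particular direction. Compound 3 is therefore estimated at 9 mL.min-1.g-1, with a range from 4 mL.min-1.g-1 to 20 mL.min-1.g-1.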

Compound 3, intrinsic clearance in microsomes: 14 mL.min-1.g-1
For compound 3 the middle estimate is 1.6-fold (0.19 log units) below the measured one; measured number inside the range.
By their numbers in this assay, from the lowest: compounds 1, 2 and 3 (each within the scatter of the next).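

Among the compounds shown here, this is the first pair in the set that isolates a change at this position, on an aromatic carbon of the shared core, and in this assay placing 1-methyl-1H-pyrazol-5-yl where 2-methyl-1H-imidazol-1-yl stood gives a 1.8-fold higher number from compound 1 to compound 3 (0.24 log units; within the scatter). The two groups have the same heavy-atom count and the same hydrogen-bond counts but are joined differently, and on this read-out that rearrangement of atoms cannot be told apart from the ordinary spread of repeated measurements, so this single pair gives no sign that the choice between these two rings matters here. No measurement is available that would link either ring to how quickly the compounds are cleared.

Going by these compounds, all of this rests on one pair of closely matched five-membered aromatic rings, so it remains open how the same position would respond to a different kind of group, such as a primary amine, a carboxylic acid or a saturated morpholine ring. On these data alone, it also remains open whether the same swap would give a similar result on the core of compound 2.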